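Changing the acyl cap of compound 2: clearance outlook

The source may report more compounds than this note shows. Statements on the series, on what has been measured and on what is new or still open speak of the compounds shown alone.

The series is followed in an ADME assay on cells (Hepatocyte, Rattus norvegicus) for metabolic stability; a lower number here means slower removal, a higher number faster removal of the compound. Compound 1 `Cc1ccc2[nH]c(C(=O)N[C@H]3CN(S(=O)(=O)c4ccccc4)C[C@@H]3C(=O)N[C@@H]3CCCN(C)C3)cc2c1` gives 23 uL/min in this assay. Compound 2 `Cc1csc(C(=O)N[C@H]2CN(S(=O)(=O)c3ccccc3)C[C@@H]2C(=O)N[C@H]2CCCNC2)n1` gives only a limit in this assay, < 1 uL/min; this is the limit of < 1 uL/min in this assay, at which 1 of the 2 values shown sits, so where compound 2 truly sits under that limit is not known. Compound 3 `O=C(N[C@H]1CN(S(=O)(=O)c2ccccc2)C[C@@H]1C(=O)N[C@H]1CCCNC1)c1nnc(-c2ccc(F)cc2)s1` carries, in place of the group on compound 2, the change (a group of 12 heavy atoms (8 carbon, 2 nitrogen, 1 fluorine, 1 sulfur; one five-membered aromatic ring with 3 hetero atoms, one six-membered aromatic ring of carbon only) in place of a group of 6 heavy atoms (4 carbon, 1 nitrogen, 1 sulfur; one five-membered aromatic ring with 2 hetero atoms), on a carbonyl carbon). No measured pair covers this exchange, so the size of the step cannot be read from the data shown. In this assay a move toward faster removal is expected for this change, likely beyond the usual scatter but still modest, with the step from compound 2 to compound 3 estimated at an at least 3.0-fold higher number from compound 2 to compound 3 (0.47 log units; beyond the scatter). Compound 3 is expected to give 3 uL/min, within a range of 1 uL/min to 12 uL/min, and there remains a fair chance that this assay again reports only a limit for compound 3.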

Compound 3, intrinsic clearance in a liver preparation (reported as CLH), per the amount of preparation that the assay uses: 1.2 uL/min
Estimate against measurement, compound 3: 2.5-fold (0.40 log units) above; low and high end bracket the measured number.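

Exchanging the 4-methyl-1,3-thiazol-2-yl on the carbonyl carbon for the larger group with two aromatic rings gives an at least 1.2-fold higher number from compound 2 to compound 3 (0.07 log units; that floor lies within the scatter). Compound 2 stands at a limit and not at a number, so only this floor of the step can be read: the limit of < 1 uL/min in this assay, at which 1 of the 3 values shown sits.

In this assay compound 3 gives 1.2 uL/min, so this position takes the larger group, with its added six-membered aromatic ring, and the read-out stays a low number.

The compounds shown leave open which part of the entering group carries any change, the five-membered ring with its hetero atoms or the fluorine-bearing six-membered ring, for both enter together. Also open, going by these compounds, is how this assay would read with a carboxylic acid or an amine in place of the fluorine.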